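The compounds below may be only part of what the source reports. "The series", "measured", "known", "first", "only" and "open" are said of these compounds alone.

Two compounds share one core and differ only in the group on a triple-bonded carbon. Compound 1 `CC1(C#Cc2c(Cl)c3c(Cl)cc(C(N)=O)nc3n2[C@H]2CCCNC2)COC1` gives 119 nM in a functional assay on KG-1 cells (Homo sapiens) for antiproliferative activity (on this read-out higher numbers stand for an effect only at larger amounts of compound and lower numbers for an effect already at smaller amounts), and compound 2 `NC(=O)c1cc(Cl)c2c(Cl)c(C#CC3CCOCC3)n([C@H]3CCCNC3)c2n1` gives 69 nM in this assay. The step of a 1.7-fold lower number from compound 1 to compound 2 (0.24 log units; within the scatter) is within the usual scatter, so these two numbers cannot be told apart. Among the two measured compounds, compound 2 stands at the lower number, and its only neighbour, compound 1, lies within the scatter of it. Compound 3 `CC(O)C#Cc1c(Cl)c2c(Cl)cc(C(N)=O)nc2n1[C@H]1CCCNC1` differs from compound 2 by 1-hydroxyethyl in place of oxan-4-yl on a triple-bonded carbon. Among the measured compounds shown here, the only measured step that bears on this position is a 1.7-fold lower number from compound 1 to compound 2 (0.24 log units; within the scatter), where one ring-bearing group replaced another on the same carbon without a change beyond the scatter. For the measured compounds named here, no measured step covers a group with no ring or with a hydrogen-bond donor there. For this step the expected outcome is a 1.4-fold higher number from compound 2 to compound 3 (0.16 log units; within the scatter), with no direction beyond the scatter. Compound 3 is estimated at 100 nM in this assay, within a range from 35 nM to 300 nM.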

Compound 3, half-maximal effective concentration: 147 nM
Compound 3: the middle estimate sits 1.5-fold (0.17 log units) below what was measured, and the stated range covers the measured number.
By their numbers in this assay, from the lowest: compounds 2, 1 and 3 (each within the scatter of the next, the first and the last beyond it).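

Swapping oxan-4-yl for 1-hydroxyethyl on this triple-bonded carbon gives, in this assay, a 2.1-fold higher number from compound 2 to compound 3 (0.33 log units; beyond the scatter) and so moves the number beyond the scatter for the first time at this position, though only modestly. Replacing 3-methyloxetan-3-yl with the same group gives a 1.2-fold higher number from compound 1 to compound 3 (0.09 log units; within the scatter) and stays within the scatter, so a group with no ring can still read like one of the two ring-bearing groups. No measurement shown accounts for the difference between these two steps.

The ring, the size and the hydrogen-bond donor all change together here, so their separate contributions remain unresolved. As far as these compounds go, a 1-methoxyethyl group would keep the chain without the hydroxyl hydrogen, and an aminomethyl group or a carboxylic acid would put other atoms at this place, so their outcomes remain open.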